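Stilbene series: pyrrolidine substituent and configuration on HepG2 cells

The source may hold more compounds than are shown below. What is called first, only, known or untested is meant among the compounds shown, and "the series" means these compounds.

Of the compounds shown here, three built on one shared core have been measured in a functional assay on HepG2 cells (Homo sapiens) for antiproliferative activity, read by CCK-8 assay, with a stated time of 48 h; a lower number here means a stronger inhibitor, a higher number a weaker inhibitor. Compound 1 `COc1ccc(/C=C\c2cc(OC)c(OC)c(OC)c2)cc1OCc1ccc(CN2CC[C@H](C(=O)O)C2)cc1` gives 6400 nM in this assay. Compound 2 `COc1ccc(/C=C\c2cc(OC)c(OC)c(OC)c2)cc1OCc1ccc(CN2CC[C@H](O)C2)cc1` differs from compound 1 in that (hydroxy in place of carboxy on a saturated ring carbon); compound 2 gives 6600 nM, and the step is a 1.0-fold higher number from compound 1 to compound 2 (0.01 log units; within the scatter). Compound 3 `COc1ccc(/C=C\c2cc(OC)c(OC)c(OC)c2)cc1OCc1ccc(CN2CC[C@@H](C(=O)O)C2)cc1` differs from compound 1 only in that (the two compounds have the same atoms and bonds and differ only in configuration as drawn: 1 of 2 stereo elements differ; a stereocentre at a saturated ring carbon is drawn S in compound 1 and R in compound 3); compound 3 gives 2300 nM, and that step is a 2.8-fold lower number from compound 1 to compound 3 (0.44 log units; beyond the scatter), while the step from compound 2 is a 2.9-fold lower number from compound 2 to compound 3 (0.46 log units; beyond the scatter). Thus within this set, compound 3 has the lowest number, and the only difference from compound 1 is the configuration drawn at the pyrrolidine ring (the fact that compounds 1 and 3 differ only in the configuration as drawn).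

Compound 4 `COc1ccc(/C=C\c2cc(OC)c(OC)c(OC)c2)cc1OCc1ccc(CN2CC[C@@H](O)C2)cc1` has not yet been measured in this assay. It differs from compound 3 in that (hydroxy in place of carboxy on a saturated ring carbon), which is the same change as from compound 1 to compound 2, and it stands on the core of compound 3 rather than on that of compound 1. For the measured compounds named here, the one measured example of this change, a 1.0-fold higher number from compound 1 to compound 2 (0.01 log units; within the scatter), stayed within the scatter, so the expectation is that compound 4 will give a number near that of compound 3, with the step from compound 3 to compound 4 expected to be a 1.2-fold higher number from compound 3 to compound 4 (0.09 log units; within the scatter). Going by the values given here, since only one pair shows this change, and the configuration at the ring carbon is known to matter for the carboxy compounds, the expectation is held loosely. Compound 4 is therefore estimated at 2800 nM, with a range from 1200 nM to 6500 nM.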

Compound 4, half-maximal inhibitory concentration: 6200 nM
Estimate against measurement, compound 4: 2.2-fold (0.35 log units) below; the range from low to high includes it.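

In this assay the change from carboxy to hydroxy gives a 2.7-fold higher number from compound 3 to compound 4 (0.43 log units; beyond the scatter) on the core of compound 3 and a 1.0-fold higher number from compound 1 to compound 2 (0.01 log units; within the scatter) on the core of compound 1, so only the first step stands beyond the scatter, yet the gap between the two steps does not show that they truly differ: the same change on two cores in this assay, a 1.0-fold higher number (0.01 log units; within the scatter) from compound 1 to compound 2 and a 2.7-fold higher number (0.43 log units; beyond the scatter) from compound 3 to compound 4, 2.6-fold (0.42 log units) apart, within the scatter of two such steps. Compound 4 and compound 2 share the hydroxy group and show no separation, with a 1.1-fold lower number from compound 2 to compound 4 (0.03 log units; within the scatter) and the same holds for compound 4 against the carboxy compound 1, with a 1.0-fold lower number from compound 1 to compound 4 (0.01 log units; within the scatter) so that compound 3 alone stands apart from the other three, although the two hydroxy compounds differ only in this way: the fact that compounds 2 and 4 differ only in the configuration as drawn. With a single pair on each core, these numbers neither show that the change carries over unaltered from one core to the other nor establish that its effect depends on the configuration at the ring carbon.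

On these data alone, it remains open whether an amine, a primary amide or a methyl ester at the same ring carbon would follow compound 3 or the other three compounds. As far as these compounds go, it also remains open whether a carboxylic acid on a longer chain would keep the same dependence on configuration.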